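This account rests on a few compounds, and the source may have more. Where it says the series, first, only, none or still open, it means among the compounds named here.

Measured in a functional assay on HCT-15 cells (Homo sapiens) for cytotoxicity, in the presence of a further agent that is not named here; on this read-out higher numbers stand for weaker inhibition and lower numbers for stronger inhibition:

Compound 1 `Clc1ccc(-c2cc(-c3ccsc3)nc(-c3ccccc3Cl)c2)o1`: 4570 nM
Compound 2 `Cc1ccc(-c2cc(-c3ccoc3)cc(-c3ccsc3)n2)cc1`: 44800 nM

Compound 2 stands highest of the two at 44800 nM, which makes it the weaker inhibitor, and its gap to compound 1 lies beyond the scatter. Compound 3 `Clc1ccc(-c2cc(-c3ccoc3)cc(-c3ccsc3)n2)cc1` keeps the rest of compound 2 and changes 4-methylphenyl to 4-chlorophenyl, with chloro in place of methyl on an aromatic carbon. Among the compounds with values here, no measured pair shows this change on its own, so any expectation is loose. Within the data shown here, the only hint is that compound 1, which carries chloro groups, gives 4570 nM, though it differs from compound 2 in more than one place. A moderate move to a lower number in this assay is therefore expected, while a result within the scatter remains possible. The expected step is a 2.6-fold lower number from compound 2 to compound 3 (0.42 log units; beyond the scatter). For compound 3 the estimated value is 17000 nM, with an expected range of 5000 nM to 50000 nM.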

Compound 3, half-maximal inhibitory concentration: > 100000 nM
Compound 3 gave a limit, no number; the forecaster's own chance of this, stated with the estimate: 10%; middle value at least 5.8-fold (0.76 log units) away from the limit.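

In this assay, chloro in place of methyl on the six-membered aromatic ring, para to a large group, moves the read-out towards weaker inhibition: the change gives an at least 2.2-fold higher number from compound 2 to compound 3 (0.34 log units; beyond the scatter). This is the first step shown that alters a single place, and with the rest of compound 2 held fixed, chloro at this position brings no lower number. The result for compound 3 is a limit of the assay and not a number, so the full size of the step stays unknown: the limit of > 100000 nM in this assay, at which 1 of the 3 values shown sits.

On these data alone, with only methyl and chloro compared at this position, it remains open how a different group there, such as an amine or a carboxylic acid, would read out. As far as these compounds go, it is also open whether the same change would act alike on the core of compound 1.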